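A few compounds are considered here, and "the series" means these few. Any claim that something is new, unique, unknown or untested is made for them only; others in the source may bear on it.

Measured in a functional assay on A549 cells (Homo sapiens) for inhibition, read by MTT assay, with a stated time of 48 h; on this read-out higher numbers stand for weaker inhibition and lower numbers for stronger inhibition:
compound 1 `C[Se]c1ccc(N(C)c2nc(C3CC3)nc3ccccc23)cc1` gives 13 nM
compound 2 `COc1ccc(N(C)c2nc(C)nc3ccccc23)cc1C(=O)NCC[Se]C#N` gives 187 nM
compound 3 `Cc1nc(N(C)c2ccc([Se]C#N)c(Cl)c2)c2ccccc2n1` gives 7 nM

Compound 2 holds the highest of the three numbers and so shows the weakest inhibition, with its gaps to both other compounds lying beyond the scatter. Compound 4 `COc1ccc(N(C)c2nc(C)nc3ccccc23)cc1` differs from compound 2 at one place, on an aromatic carbon, where a hydrogen atom takes the place of a large group (a hydrogen atom in place of a group of 8 heavy atoms (4 carbon, 2 nitrogen, 1 oxygen, 1 selenium; no ring), on an aromatic carbon). The methoxy group stays on the ring.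

For the measured compounds named here, no step between measured compounds is available, so the expectation rests on their values alone. Compound 1 reaches 13 nM and compound 3 reaches 7 nM without the group that leaves, which points towards a lower number. One doubt remains: every measured compound contains selenium and compound 4 has none, so the data cannot show what its absence does here. Even so, the estimated step is a fall beyond the scatter, towards stronger inhibition, given as a 19-fold lower number from compound 2 to compound 4 (1.27 log units; beyond the scatter) in the expected direction. For compound 4 the expected value is 10 nM, within an estimated range from 2 nM to 50 nM.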

Compound 4, half-maximal inhibitory concentration: 3 nM
For compound 4 the middle estimate is 3.3-fold (0.52 log units) above the measured one; low and high end bracket the measured number.
By their numbers in this assay, from the lowest: compound 4; then compounds 3 and 1 (each within the scatter of the next); then compound 2.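

In this assay, replacing the group of 8 heavy atoms by a hydrogen atom on this aromatic carbon, ortho to a methoxy group, leads to a 62-fold lower number from compound 2 to compound 4 (1.79 log units; beyond the scatter) in the direction of stronger inhibition. Compound 1 and compound 3 both contain selenium, as does compound 2, so only compound 4 shows that a number this low on this read-out can be reached on this scaffold with no selenium at all, and that this large group is not needed at this position for that result. Nothing measured on the compounds here accounts for the size of this step.

For the compounds shown here, the single step removes the whole group at once, so it remains open which part of the group goes with the weaker inhibition, and whether a smaller replacement such as a primary amide, a carboxylic acid or a plain methyl group on the same carbon would give a number closer to compound 4 or to compound 2. Also open, from the compounds shown here alone, is whether a sulfur atom in place of the selenium in the chain of compound 2 would change its number, and whether the same removal would give a step of similar size without the methoxy group on the ring.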